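Extending the acetamido chain on compound 3

The source may hold more compounds than are shown below. What is called first, only, known or untested is meant among the compounds shown, and "the series" means these compounds.

Measured compounds:
- compound 1, `CCC(CC)OC(=O)c1cn(Cc2ccccc2F)c2cc(-c3ccc(OC)cc3)c(CN(C)Cc3ccccc3)n2c1=O`, in an assay on HEK293 cells for binding affinity to Gonadotropin-releasing hormone receptor (Homo sapiens), read by radioligand binding (on this read-out lower numbers stand for stronger inhibition and higher numbers for weaker inhibition), compound 1 gives 62 nM
- compound 2, `CCC(CC)OC(=O)c1cn(Cc2ccccc2F)c2cc(-c3ccc(N)cc3)c(CN(C)Cc3ccccc3)n2c1=O`, compound 2 gives 100 nM
- compound 3, `CCC(CC)OC(=O)c1cn(Cc2ccccc2F)c2cc(-c3ccc(NC(C)=O)cc3)c(CN(C)Cc3ccccc3)n2c1=O`, compound 3 gives 4 nM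

Compound 3 has the lowest number of the three. Its step from compound 1 is a 16-fold lower number from compound 1 to compound 3 (1.19 log units; beyond the scatter), and from compound 2 it is a 25-fold lower number from compound 2 to compound 3 (1.40 log units; beyond the scatter); both are large and beyond the scatter, so compound 3 stands clearly apart. Between compound 1 and compound 2 the step is a 1.6-fold higher number from compound 1 to compound 2 (0.21 log units; within the scatter), which stays within the scatter.

Compound 4, `CCCC(=O)Nc1ccc(-c2cc3n(Cc4ccccc4F)cc(C(=O)OC(CC)CC)c(=O)n3c2CN(C)Cc2ccccc2)cc1`, differs from compound 3 by ethyl in place of hydrogen on a saturated chain carbon bound to a carbonyl carbon. The measured steps show that the acetyl on the aromatic nitrogen matters a great deal, as the large steps from compound 1 and compound 2 to compound 3 both reach the acetamido compound. Among the compounds with values here, none of the measured steps, however, lengthens that chain, so there is no direct precedent for ethyl in place of hydrogen on the saturated chain carbon bound to the carbonyl carbon. Compound 4 is therefore expected to stay close to compound 3, with a step of a 1.3-fold higher number from compound 3 to compound 4 (0.10 log units; within the scatter), not beyond the scatter. The estimate for compound 4 is 5 nM, within a range of 1.5 nM to 16 nM.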

Compound 4, inhibition constant: 3.8 nM
The estimate for compound 4 lay 1.3-fold (0.12 log units) above the measured number; the range from low to high includes it.
By their numbers in this assay, from the lowest: compounds 4 and 3 (each within the scatter of the next); then compounds 1 and 2 (each within the scatter of the next).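

In this assay, ethyl in place of hydrogen on a saturated chain carbon bound to a carbonyl carbon gives a 1.1-fold lower number from compound 3 to compound 4 (0.02 log units; within the scatter) and stays within the scatter, so this spot on the chain accepts the ethyl with no change the assay can resolve. The large advantage over the other two compounds is therefore not confined to the acetyl: propylcarbonyl in place of hydrogen on the nitrogen gives a 26-fold lower number from compound 2 to compound 4 (1.42 log units; beyond the scatter) and (propylcarbonyl)amino in place of methoxy gives a 16-fold lower number from compound 1 to compound 4 (1.21 log units; beyond the scatter) and both steps are large and beyond the scatter. No measurement shown here explains why the added ethyl leaves the number where it stands.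

How far this tolerance reaches remains open, since the compounds shown do not say whether a longer chain, a branched chain or a phenyl ring on the carbonyl would hold the number. Also open, going by these compounds, is whether an amine or a carboxylic acid at the end of the chain would be accepted as the plain ethyl is.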